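Removing One Fluorine from a Potent Urea Antagonist

A few compounds are considered here, and "the series" means these few. Any claim that something is new, unique, unknown or untested is made for them only; others in the source may bear on it.

Three measured compounds share one core and differ only in the aromatic group on the ring nitrogen. In a functional assay for antagonist activity at transient receptor potential cation channel subfamily V member 1 (Rattus norvegicus), read by FLIPR (on this read-out lower numbers stand for lower potency and higher numbers for higher potency (the scale is a negative logarithm)), compound 1 `N#Cc1ccc(N2CC[C@@H](NC(=O)Nc3ccccc3Br)C2)nc1` gives 6.7. The value of compound 2 `O=C(Nc1ccccc1Br)N[C@@H]1CCN(c2ccccn2)C1` is a limit of the assay rather than a number: < 6.6. That is the limit of < 6.6 in this assay, at which 1 of the 3 values shown sits. Compound 3 `O=C(Nc1ccccc1Br)N[C@@H]1CCN(c2ccc(F)c(F)c2)C1` gives 8.1, the highest of the two numbers, with compound 1 the nearest at a number 1.40 log units higher from compound 1 to compound 3 (beyond the scatter). The other step to it, a number at least 1.50 log units higher from compound 2 to compound 3 (beyond the scatter), is also large.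

Compound 4 `O=C(Nc1ccccc1Br)N[C@@H]1CCN(c2cccc(F)c2)C1` differs from compound 3 by hydrogen in place of fluoro on an aromatic carbon. Within the data shown here, no measured step removes a fluoro from this ring. Among the measured compounds shown here, the steps that swapped the whole aromatic group, a number 1.40 log units higher from compound 1 to compound 3 (beyond the scatter) and a number at least 1.50 log units higher from compound 2 to compound 3 (beyond the scatter), were large, while the only step that removed a single small group, a number at least 0.10 log units lower from compound 1 to compound 2 (that floor lies within the scatter), stayed small. A small change is therefore expected, a number 0.30 log units lower from compound 3 to compound 4 (within the scatter). Compound 4 is expected to give about 7.8 in this assay, within the range 7.2 to 8.4.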

Compound 4, negative logarithm of the antagonist equilibrium constant in the transient receptor potential cation channel subfamily V member 1 assay: 7.8
Beside the measured number, compound 4's estimate shows no gap at the digits printed; the measured number falls inside the stated range.
By their numbers in the transient receptor potential cation channel subfamily V member 1 assay, from the lowest: compound 1; then compounds 4 and 3 (each within the scatter of the next). At a limit, below all of these: compound 2.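

In the transient receptor potential cation channel subfamily V member 1 assay, the earlier large steps swapped the whole aromatic group, whereas this one changes a single atom on the phenyl ring, going from 3,4-difluorophenyl to 3-fluorophenyl, and it stays small: a number 0.30 log units lower from compound 3 to compound 4 (within the scatter). With only one fluoro left, the large steps up from the two pyridine-bearing compounds remain, namely a number 1.10 log units higher from compound 1 to compound 4 (beyond the scatter) and a number at least 1.20 log units higher from compound 2 to compound 4 (beyond the scatter). In a physicochemical assay for solubility (a lower number here means a less soluble compound, a higher number a more soluble compound), compound 3 gives < 100 ug/mL as a limit of the assay and not a number. In the physicochemical assay compound 4 gives < 100 ug/mL as a limit of the assay as well. In the physicochemical assay, the step between compound 3 and compound 4 cannot be read, as both compounds sit at a limit of the assay: the limit of < 100 ug/mL in the physicochemical assay, at which 2 of the 2 values shown sit.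

From the compounds shown here alone, what a plain phenyl group on the ring nitrogen would give, with no fluoro at all, stays open. So does what a chloro or a methoxy group would do on this aromatic carbon in place of the fluoro.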